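Changing the chain of compound 1 in the MCF7 assay

The compounds below may be only part of what the source reports. "The series", "measured", "known", "first", "only" and "open" are said of these compounds alone.

Measured in a functional assay on MCF7 cells (Homo sapiens) for antiproliferative activity, read by MTT assay; a lower number here means a stronger inhibitor, a higher number a weaker inhibitor:
compound 1 `CC/C=C\C/C=C\C/C=C\CCCCCCCc1cc(=O)c2c(O)cc(OCOC)c(C)c2o1`: 17500 nM
compound 2 `CC/C=C\C/C=C\C/C=C\CCCCCCCc1cc(=O)c2c(O)cc(OCOC)cc2o1`: 17500 nM
compound 3 `CC/C=C\C/C=C\C/C=C\CCCCCCCc1cc(=O)c2c(O)c(C)c(OCOC)c(C)c2o1`: > 84100 nM (a limit of the assay)

Compound 1 stands level with compound 2 in this assay, and the two share the same reading. Compound 3 is known only through (the limit of > 84100 nM in this assay, at which 1 of the 3 values shown sits).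

Compound 4 `CCCC/C=C\CCCCCCCCCc1cc(=O)c2c(O)cc(OCOC)c(C)c2o1` keeps the core of compound 1 and alters only the chain: a group of 8 heavy atoms (8 carbon; no ring) in place of a group of 10 heavy atoms (10 carbon; no ring), on a saturated chain carbon, seven bonds along the chain from an aromatic carbon. Oct-3-en-1-yl enters on a saturated chain carbon, seven bonds along the chain from an aromatic carbon.

Two measured steps start from compound 1, and both concern a methyl or a hydrogen on an aromatic carbon. One is no change at the digits printed from compound 1 to compound 2 (within the scatter), and the other is an at least 4.8-fold higher number from compound 1 to compound 3 (0.68 log units; beyond the scatter). Among the compounds with values here, neither changes the chain, so they give only indirect guidance, and no measured pair shows what a chain change does here. From the compounds shown here alone, with that gap, no step beyond the scatter is expected in this assay, though a move in either direction remains open and the range is kept wide. The expected change is a 1.1-fold higher number from compound 1 to compound 4 (0.06 log units; within the scatter). For compound 4 the estimated value is 20000 nM, with an expected range from 7000 nM to 60000 nM.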

Compound 4, half-maximal inhibitory concentration: > 67200 nM
Compound 4 ended at the assay's limit (the forecaster's own chance of this, stated with the estimate: 15%); at least 3.3-fold (0.52 log units) between middle value and limit.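

In this assay, oct-3-en-1-yl in place of the group of 10 heavy atoms, on a saturated chain carbon, seven bonds along the chain from an aromatic carbon, gives an at least 3.8-fold higher number from compound 1 to compound 4 (0.58 log units; beyond the scatter). Within the data shown here, this is the first measured step that changes the chain, and it shows that the reading responds to the chain as well as to a methyl or a hydrogen on an aromatic carbon, with the step lying beyond the scatter. Compound 4 has a limit of the assay rather than a number, so the step gives only a lower bound on the loss and its full size stays unknown: the limit of > 67200 nM in this assay, at which 1 of the 4 values shown sits.

The change alters the count of heavy atoms and the count of double bonds outside aromatic rings at the same time, and the compounds shown do not tell which of the two differences carries the step. From the compounds shown here alone, an octyl chain with no double bond, or a longer chain with a single double bond, would separate the two, and whether any chain gives a lower number than compound 1 also stays open.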